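A few compounds are considered here, and "the series" means these few. Any claim that something is new, unique, unknown or untested is made for them only; others in the source may bear on it.

Measured compounds:
compound 1, `O=C(NO)c1ccc(NCc2nc(-c3cccnc3)nn2-c2ccccc2)cc1`: 57.7%
compound 2, `COc1ccc(-n2nc(-c3ccccc3)nc2CNc2ccc(C(=O)NO)cc2)cc1`: 63.4%
compound 3, `O=C(O)c1ccc(NCc2nc(-c3ccccc3)nn2-c2ccccc2)cc1`: -0.4%

In an assay on Sf9 cells for inhibition of protein deacetylase HDAC6 (Homo sapiens), read by fluorescence, with a stated time of 40 min, tested at 100 nM (a higher number here means more inhibition at the concentration tested (going by the name of the read-out), a lower number less inhibition), compound 1 gives 57.7%, the second highest of the three numbers. Compound 2 gives 63.4% in this assay, and the gap to compound 1 lies within the scatter, so the two are not told apart here. Compound 3, with -0.4% in this assay, sits far lower than compound 1, a gap well beyond the scatter.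

Compound 4 is `O=C(NO)c1ccc(NCc2nc(-c3ccc(C(F)(F)F)cc3)nn2-c2ccccc2)cc1`. Against compound 1 the change is 4-(trifluoromethyl)phenyl in place of pyridin-3-yl on an aromatic carbon. No step between measured compounds covers this kind of change, so the expectation rests on the numbers shown alone: compound 1 and compound 2 carry different aromatic groups at that carbon of the shared core and give numbers within the scatter of each other, so the inhibition in this assay is level across that exchange of a six-membered aromatic ring. The step of a number 2.3 percentage points higher from compound 1 to compound 4 (within the scatter) is therefore expected to be small, in no firm direction, and within the scatter. Compound 4 is expected to give about 60% in this assay, with a range from 40% to 78%.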

Compound 4, a percentage reported as inhibition, at one concentration (the size of the read-out at that concentration, not a potency): 41.6%
Estimate against measurement, compound 4: 18.4 percentage points above; the measured number falls inside the stated range.
By their numbers in this assay, from the lowest: compound 3; then compound 4; then compounds 1 and 2 (each within the scatter of the next).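

In this assay the aromatic carbon of the five-membered ring, between two ring nitrogen atoms, proves sensitive to the group it carries: with 4-(trifluoromethyl)phenyl in place of pyridin-3-yl there is a number 16.1 percentage points lower from compound 1 to compound 4 (beyond the scatter). Within the data shown here, the change is therefore the first single-place exchange with a readable outcome, and it shows that a six-membered aromatic ring at this carbon does not guarantee level inhibition. The exchange removes a ring nitrogen and adds a trifluoromethyl group at once, and nothing at hand bears on why the number falls.

Which of those two differences carries the step stays open, and a direct comparison would need the plain phenyl group, or pyridin-4-yl, at this carbon on the core of compound 1. Also open, going by these compounds, is how other groups on the para-free ring carbon compare, such as an amine or a carboxylic acid in place of the trifluoromethyl group of compound 4, and whether the step would persist as a potency rather than a read-out at one concentration.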